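Swapping a Thiophene for Fluorophenyl on an Agonist Core

The source may report more compounds than this note shows. Statements on the series, on what has been measured and on what is new or still open speak of the compounds shown alone.

Of the compounds shown here, three built on the same acid-bearing core have so far been tested in a functional assay on CHO cells for agonist activity at Free fatty acid receptor 1 (Homo sapiens), read by FLIPR and calcium flux, tested at 100 nM; on this read-out lower numbers stand for a weaker effect and higher numbers for a stronger effect at the one concentration tested. Compound 1 `O=C(O)CC1COc2cc(OCc3nnc(-c4ccccc4)o3)ccc21` gives 1.54%. Compound 2 `O=C(O)CC1COc2cc(OCc3csc(-c4ccccc4)n3)ccc21` gives 0.15%. Compound 3 `Cc1nc(-c2ccsc2)sc1COc1ccc2c(c1)OCC2CC(=O)O` gives 56.5%, the highest of the three numbers: the nearest, compound 1, lies far below it, beyond the scatter, and compound 2 lies further still. Compound 1 and compound 2 sit within the scatter of each other, so nothing separates those two.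

Compound 4 `Cc1nc(-c2ccccc2F)sc1COc1ccc2c(c1)OCC2CC(=O)O` has not yet been measured. It differs from compound 3 in one place: 2-fluorophenyl in place of thiophen-3-yl on an aromatic carbon. The rest of the molecule is unchanged. Among the measured compounds shown here, no pair among the measured compounds shows this particular exchange, and compounds 1 and 2 differ from compound 3 in more than this one place, so their gaps to compound 3 say nothing about the new step. A ring of similar size on the same position is expected to give a step of a number 8.5 percentage points lower from compound 3 to compound 4 (within the scatter) that stays within the scatter or amounts to a modest fall. Compound 4 is therefore expected to give about 48%, with a range from 22% to 72%.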

Compound 4, a percentage reported as activity, at one concentration (the size of the read-out at that concentration, not a potency): 25.8%
For compound 4 the middle estimate is 22.2 percentage points above the measured one, and the stated range covers the measured number.
By their numbers in this assay, from the lowest: compounds 2 and 1 (each within the scatter of the next); then compound 4; then compound 3.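

In this assay, the exchange of thiophen-3-yl for 2-fluorophenyl gives a number 30.7 percentage points lower from compound 3 to compound 4 (beyond the scatter). Among the compounds shown here, this is the first direct, one-place comparison, and it shows that the aromatic carbon next to the ring nitrogen and next to the ring sulfur is sensitive to which aromatic ring it carries, even though both groups are single aromatic rings without a net charge. Compound 4 still gives 25.8%, so at the one concentration tested a six-membered aromatic ring of carbon only keeps part of the read-out, but nothing available accounts for the fall.

This single step changes ring size, the hetero atom and the fluorine together, so the compounds shown leave open which of these differences matters: unsubstituted phenyl at this position would separate the ring from the fluorine, and 3-fluorophenyl or 4-fluorophenyl would test where the fluorine sits. Thiophen-2-yl would likewise show whether the way the thiophene is attached matters as well.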